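Extending an Alkoxy Group on a Positive Allosteric Modulator

The compounds below may be only part of what the source reports. "The series", "measured", "known", "first", "only" and "open" are said of these compounds alone.

Compound 1 `CC(C)CCn1ccc(-c2ccccc2)c(C#N)c1=O`: 117%
Compound 2 `COc1cccc(-c2ccn(CCC(C)C)c(=O)c2C#N)c1`: 176%

In a functional assay on CHO cells for positive allosteric modulation of metabotropic glutamate receptor 2 (Homo sapiens), read by scintillation counting and GTPgammaS binding, with a stated time of 30 min (a lower number here means a smaller maximal response, a higher number a larger maximal response), compound 1 gives 117%, the lower of the two measured numbers, while compound 2 gives 176%. Going by the values given here, the single measured step, a number 59 percentage points higher from compound 1 to compound 2 (beyond the scatter), is large. Compound 3 `CC(C)CCn1ccc(-c2ccc(OCC3CC3)cc2)c(C#N)c1=O` differs from compound 1 by cyclopropylmethoxy in place of hydrogen on an aromatic carbon. Among the compounds with values here, only the step from compound 1 to compound 2 bears on this, since it too adds an alkoxy group on the same ring; the new group is larger and sits para to a large group, so a rise is expected, with wide uncertainty. For compound 3 the expected value is 150% (range 105% to 200%), an expected step of a number 33 percentage points higher from compound 1 to compound 3 (beyond the scatter).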

Compound 3, largest response reached (Emax), in percent of the reference or control that the assay uses: 192%
Compound 3: middle estimate off by 42 percentage points, on the low side, within the range that was stated.
By their numbers in this assay, from the lowest: compound 1; then compound 2; then compound 3.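

In this assay, cyclopropylmethoxy in place of hydrogen on an aromatic carbon, para to a large group, gives a number 75 percentage points higher from compound 1 to compound 3 (beyond the scatter). This shows that this position accepts a group of 5 heavy atoms with a three-membered ring, and that the maximal response rises well beyond that of the shared core. Nothing available here accounts for the rise. From the compounds shown here alone, it remains open whether the three-membered ring itself matters, and how an amine, a carboxylic acid or a longer alkoxy chain on this same carbon would change the response.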